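The compounds below may be only part of what the source reports. "The series", "measured", "known", "first", "only" and "open" are said of these compounds alone.

Measured so far:
- compound 1, `C=CCn1c(=O)/c(=C\c2ccc(F)c(Br)c2)[nH]c(=O)/c1=C\c1ccccc1OC`: "not active" (no number reported)
- compound 2, `C=CCn1c(=O)/c(=C\c2cccc(Br)c2)[nH]c(=O)/c1=C\c1ccccc1OC`: 5400 nM
- compound 3, `C=CCn1c(=O)/c(=C\c2ccccc2F)[nH]c(=O)/c1=C\c1ccccc1OC`: "not active" (no number reported)

All three share one core and differ only in the aromatic group attached to one of its two double-bonded chain carbons. Among the measured compounds shown here, in a functional assay on A549 cells (Homo sapiens) for cytotoxicity, read by CCK-8 assay, with a stated time of 72 h (a lower number here means a stronger inhibitor, a higher number a weaker inhibitor), compound 2 gives 5400 nM, the only numeric value in this set. Compound 3 is reported in this assay as "not active" (no number reported), so no number is given for it, and compound 1 stands the same way. Compound 3 therefore has no measured position on the scale; it is simply one of two compounds for which no single number was obtained.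

For the measured compounds named here, the next compound, compound 4, `C=CCn1c(=O)/c(=C\c2ccc(Cl)c(Cl)c2)[nH]c(=O)/c1=C\c1ccccc1OC`, changes only that aromatic group: 3,4-dichlorophenyl in place of 2-fluorophenyl on a double-bonded chain carbon bound to an aromatic carbon. Going by the values given here, with no measured step between compounds of this kind, no size or direction can be read from the data; the only numeric anchor is compound 2. Compound 4 is expected to be a weak inhibitor at best, with a substantial chance that, like compound 3, no number is reported. The estimate for compound 4 in this assay is 8000 nM, expected to lie between 2500 nM and 30000 nM.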

Compound 4, half-maximal inhibitory concentration: "not active" (no number reported)
The entry for compound 4 holds no number, so the estimate cannot be set against anything.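

Compound 3 and compound 4 both come without a number, so no step can be read between them. No measurement shown here offers an explanation for either result. Among the compounds shown here, still open is how changing the aromatic group, one place at a time, shifts activity from the single numeric value of compound 2 5400 nM.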